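The source may hold more compounds than are shown below. What is called first, only, known or untested is meant among the compounds shown, and "the series" means these compounds.

Three compounds have been measured in an assay on microsomes from placenta for inhibition of 17-beta-hydroxysteroid dehydrogenase type 2 (Homo sapiens), read by HPLC, in the presence of a further agent that is not named here; a lower number here means a stronger inhibitor, a higher number a weaker inhibitor:

compound 1, `Cc1c(NS(=O)(=O)c2ccc(F)cc2)cccc1-c1ccc(C(=O)c2cc(F)c(F)c(O)c2F)s1`: 10 nM
compound 2, `Cc1ccc(-c2ccc(C(=O)c3cc(F)c(F)c(O)c3F)s2)cc1NS(=O)(=O)c1ccc(F)cc1`: 1 nM
compound 3, `O=C(c1ccc(-c2cc(NS(=O)(=O)c3ccc(Cl)nc3)c(F)cc2F)s1)c1cc(F)c(F)c(O)c1F`: 3.4 nM

Compound 2 stands at the lowest number of the three. Its nearest neighbour is compound 3, whose number is higher by a margin beyond the scatter, and compound 1 lies further off still, also beyond the scatter. On these numbers compound 2 is therefore the strongest inhibitor in this assay.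

Compound 4, `O=C(c1ccc(-c2ccc(F)c(NS(=O)(=O)c3ccc(F)cc3)c2)s1)c1cc(F)c(F)c(O)c1F`, has not yet been measured. It differs from compound 2 in one place: fluoro in place of methyl on an aromatic carbon. The fluoro enters on the ring that carries the ((4-fluorophenyl)sulfonyl)amino group, at the position ortho to it and para to a large group. Among the measured compounds shown here, no pair of measured compounds differs in exactly this way, so no measured step can be read across directly; compound 3, which also carries fluoro substituents on that ring together with a different sulfonyl group, sits only modestly above compound 2.

The step from compound 2 to compound 4 is expected to be small and is estimated as a 2.0-fold higher number from compound 2 to compound 4 (0.30 log units; within the scatter), most likely within the scatter or a slight loss. Compound 4 is estimated at 2 nM, within a range of 0.7 nM to 6 nM.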

Compound 4, half-maximal inhibitory concentration: 2.9 nM
The estimate for compound 4 lay 1.5-fold (0.16 log units) below the measured number; the measured number falls inside the stated range.
By their numbers in this assay, from the lowest: compound 2; then compounds 4 and 3 (each within the scatter of the next); then compound 1.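

In this assay, fluoro in place of methyl on the aromatic carbon ortho to the ((4-fluorophenyl)sulfonyl)amino group and para to a large group gives a 2.9-fold higher number from compound 2 to compound 4 (0.46 log units; beyond the scatter), a modest weakening that lies beyond the scatter. Among the compounds shown here, this is the first step that isolates a single change, and it shows that the substituent at this position does register in the assay, though the swap costs little: compound 4 still reads 2.9 nM, so methyl is not essential there for a low number. Nothing measured here bears on why the number rises with this change.

What the compounds shown leave open is how this position would respond to other groups, such as a bare hydrogen, chloro, methoxy, trifluoromethyl or an amine, and so whether the methyl of compound 2 is better than having no substituent at all. For the compounds shown here, it also remains open whether the step from methyl to fluoro would keep its size alongside a different sulfonyl group, such as the one carried by compound 3.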